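This account rests on a few compounds, and the source may have more. Where it says the series, first, only, none or still open, it means among the compounds named here.

Working notes on the series. The shared core is the acetamidoethyl thioether of compound 3 `CC(=O)NCCSc1ccccc1`. In an assay on NIH3T3 cells for displacement of a labelled ligand from melatonin receptor type 1A (Homo sapiens), with a stated time of 90 min (a lower number here means a stronger inhibitor, a higher number a weaker inhibitor), compound 3 gives 3800 nM. Compound 2 `COc1cccc(SCCNC(C)=O)c1` carries a methoxy on an aromatic carbon and gives 55 nM in this assay; compound 1 `COc1ccc(OC(C)CNC(C)=O)cc1`, with an ether linker in place of the thioether and a methoxy on the ring, gives 42700 nM. Among the three numbers compound 3 stands second highest: compound 1 sits above it and compound 2 well below it.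

Compound 4 `COc1ccc(SCCNC(C)=O)cc1` is not yet measured. The change from compound 3 is methoxy in place of hydrogen on an aromatic carbon. Going by the values given here, the only measured step of the same kind, though with the methoxy on a different aromatic carbon, is a 69-fold higher number from compound 2 to compound 3 (1.84 log units; beyond the scatter), which runs the opposite way to the present change. Among the compounds with values here, compound 1 also carries a methoxy para to the side chain, but its linker differs as well, so only its two values stand beside each other and no single step is read from it.

Putting the methoxy back is therefore expected to lower the number in this assay, though by less than the step from compound 2 to compound 3 since the place differs. For compound 4 the estimate is 500 nM, within 100 nM to 3000 nM, an expected step of a 7.6-fold lower number from compound 3 to compound 4 (0.88 log units; beyond the scatter).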

Compound 4, inhibition constant: 2820 nM
Compound 4: the middle estimate sits 5.6-fold (0.75 log units) below what was measured; the measured number falls inside the stated range.
By their numbers in this assay, from the lowest: compound 2; then compounds 4 and 3 (each within the scatter of the next); then compound 1.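

In this assay, methoxy para to a group of 7 heavy atoms gives a 1.3-fold lower number from compound 3 to compound 4 (0.13 log units; within the scatter), so at this place the group is not distinguished from hydrogen on the shared core. The earlier step, a 69-fold higher number from compound 2 to compound 3 (1.84 log units; beyond the scatter), therefore does not hold for methoxy on any aromatic carbon: the effect seen with compound 2 depends on where the group sits, with compound 2 at 55 nM and compound 4 at 2820 nM. No measurement offered here bears on why the two places differ.

The compounds shown leave open whether a hydroxyl, an ethoxy or a chlorine on this same carbon would separate from hydrogen. Also open, as far as these compounds go, is whether a second methoxy at this place would alter the number of compound 2.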